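Adding one methoxy group to compound 2

The source may hold more compounds than are shown below. What is called first, only, known or untested is meant among the compounds shown, and "the series" means these compounds.

In a functional assay on SMMC-7721 cells (Homo sapiens) for cytotoxicity, read by MTT assay, with a stated time of 72 h (on this read-out lower numbers stand for stronger inhibition and higher numbers for weaker inhibition), compound 2 `COc1cccc(C=C2C(=O)N(c3ccc(Cl)cc3)N(c3ccc(Cl)cc3)C2=O)c1` gives 30200 nM. Compound 1 `COc1cc(C=C2C(=O)N(c3ccc(Cl)cc3)N(c3ccc(Cl)cc3)C2=O)cc(OC)c1OC` gives 29500 nM, and these two values lie within the usual scatter of each other. Compound 3 `COc1ccc(C=C2C(=O)N(c3ccc(Cl)cc3)N(c3ccc(Cl)cc3)C2=O)cc1OC` keeps the shared core but turns 3-methoxyphenyl into 3,4-dimethoxyphenyl: methoxy in place of hydrogen on an aromatic carbon, ortho to a methoxy group and para to a large group. Going by the values given here, no measured pair shows this change alone, so no shift beyond the scatter is expected. The expected change is small, a 1.1-fold lower number from compound 2 to compound 3 (0.03 log units; within the scatter). The estimated value for compound 3 is 28000 nM, with a range from 12000 nM to 60000 nM.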

Compound 3, half-maximal inhibitory concentration: > 128000 nM
Compound 3 gave a limit, no number; the forecaster's own chance of this, stated with the estimate: 8%; middle value at least 4.5-fold (0.66 log units) away from the limit.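

In this assay, a methoxy group on this aromatic carbon, ortho to a methoxy group and para to a large group, is not the silent change that the earlier pair suggested: an at least 4.2-fold higher number from compound 2 to compound 3 (0.62 log units; beyond the scatter). Taking one methoxy away from the 3,4,5-trimethoxyphenyl ring points the same way, giving an at least 4.3-fold higher number from compound 1 to compound 3 (0.63 log units; beyond the scatter), so 3,4-dimethoxyphenyl stands apart from both neighbours. For compound 3, > 128000 nM is a limit of the assay and not a number, so both steps give only a minimum size.

On these data alone, whether a hydroxyl group, an amine or a fluorine atom at this place would act like methoxy stays open.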